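The source may hold more compounds than are shown below. What is called first, only, known or untested is meant among the compounds shown, and "the series" means these compounds.

Measured so far:
compound 1, `O=C(c1cccc(OC(F)(F)F)c1)N1CCC(N(C2CC2)S(=O)(=O)c2cccc(C(F)(F)F)c2)CC1` — 60%
compound 2, `NC(=O)c1ccccc1C(=O)N1CCC(N(C2CC2)S(=O)(=O)c2cccc(C(F)(F)F)c2)CC1` — 11%
compound 3, `O=C(c1ccc(OC(F)(F)F)cc1)N1CCC(N(C2CC2)S(=O)(=O)c2cccc(C(F)(F)F)c2)CC1` — 73%

In an assay on cells for inhibition of Voltage-dependent L-type calcium channel subunit alpha-1C (Homo sapiens), read by FLIPR and calcium flux, tested at 1 uM (a lower number here means a weaker effect, a higher number a stronger effect of the compound at the concentration tested), compound 3 stands highest of the three, with compound 1 nearest and compound 2 furthest behind it. Compound 4 is `CS(=O)(=O)c1ccc(F)cc1C(=O)N1CCC(N(C2CC2)S(=O)(=O)c2cccc(C(F)(F)F)c2)CC1`; the change from compound 3 is 5-fluoro-2-(methylsulfonyl)phenyl in place of 4-(trifluoromethoxy)phenyl on a carbonyl carbon. Among the compounds with values here, the steps that bear on this are the two into and out of the 2-carbamoylphenyl compound: a number 49 percentage points lower from compound 1 to compound 2 (beyond the scatter) and a number 62 percentage points higher from compound 2 to compound 3 (beyond the scatter), both large, against the modest a number 13 percentage points higher from compound 1 to compound 3 (beyond the scatter). The single measured substituted phenyl other than trifluoromethoxy, compound 2, gave the weakest number, so a large downward step is expected in this assay, a number 53 percentage points lower from compound 3 to compound 4 (beyond the scatter). Compound 4 is therefore estimated at 20%, within 5% to 45%.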

Compound 4, a percentage reported as inhibition, at one concentration (the size of the read-out at that concentration, not a potency): 18%
Estimate against measurement, compound 4: 2 percentage points above; the range from low to high includes it.
By their numbers in this assay, from the lowest: compounds 2 and 4 (each within the scatter of the next); then compound 1; then compound 3.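

In this assay, the 5-fluoro-2-(methylsulfonyl)phenyl group gives a second low read-out on this carbonyl carbon, so the low value no longer rests on the 2-carbamoylphenyl of compound 2 alone, with a number 7 percentage points higher from compound 2 to compound 4 (within the scatter) as the comparison. The two trifluoromethoxy compounds stay well clear of it, with a number 55 percentage points lower from compound 3 to compound 4 (beyond the scatter) and a number 42 percentage points lower from compound 1 to compound 4 (beyond the scatter) as the steps. No measurement at hand accounts for these steps.

Open, from the compounds shown here alone, is what the fluoro and methylsulfonyl parts each contribute to the entering group. Also open, going by these compounds, is whether an unsubstituted phenyl, or a phenyl carrying an amine or a carboxylic acid, would read low as well.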